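Moving the Trifluoromethyl Group Around the Benzyloxy Ring

A few compounds are considered here, and "the series" means these few. Any claim that something is new, unique, unknown or untested is made for them only; others in the source may bear on it.

Compound 1 `CCN(CC)C(=O)Cc1c(-c2ccc(OCc3ccccc3C(F)(F)F)cc2)nn2c(C)cc(C)nc12` gave 1.4 nM.
Compound 2 `CCN(CC)C(=O)Cc1c(-c2ccc(OCc3cccc(C(F)(F)F)c3)cc2)nn2c(C)cc(C)nc12` gave 0.67 nM.

In an assay on isolated protein (kidney, strain Wistar) for displacement of a labelled ligand from Translocator protein (Rattus norvegicus), read by scintillation counting, with a stated time of 90 min (on this read-out lower numbers stand for stronger inhibition and higher numbers for weaker inhibition), compound 2 stands at the lowest of the two numbers; its nearest neighbour is compound 1, and the step between them is a 2.1-fold lower number from compound 1 to compound 2 (0.32 log units; beyond the scatter). Compound 3 `CCN(CC)C(=O)Cc1c(-c2ccc(OCc3ccc(C(F)(F)F)cc3)cc2)nn2c(C)cc(C)nc12` is the next member of this series, differing from compound 2 by 4-(trifluoromethyl)phenyl in place of 3-(trifluoromethyl)phenyl on a saturated chain carbon bound to an oxygen on an aromatic ring. Going by the values given here, only the step of a 2.1-fold lower number from compound 1 to compound 2 (0.32 log units; beyond the scatter) bears on this change, and it was modest; nothing yet measured speaks to the 4-(trifluoromethyl)phenyl group itself. Compound 3 is therefore expected to stay close to compound 2, with a step of a 1.5-fold higher number from compound 2 to compound 3 (0.17 log units; within the scatter), and its estimated value is 1 nM within a range from 0.3 nM to 3 nM.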

Compound 3, inhibition constant: 1.6 nM
Compound 3: middle estimate off by 1.6-fold (0.20 log units), on the low side, within the range that was stated.
By their numbers in this assay, from the lowest: compound 2; then compounds 1 and 3 (each within the scatter of the next).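

The step of a 2.4-fold higher number from compound 2 to compound 3 (0.38 log units; beyond the scatter) shows that the result at this position depends on where the trifluoromethyl group sits, and compound 2 now has the lowest number of the three. The other step, a 1.1-fold higher number from compound 1 to compound 3 (0.06 log units; within the scatter), places the 2-(trifluoromethyl)phenyl and 4-(trifluoromethyl)phenyl groups level, so the numbers do not change steadily across the three placements. Nothing available accounts for this difference. From the compounds shown here alone, it remains open whether the 3-(trifluoromethyl)phenyl advantage would persist with a chlorine atom or a methoxy group in place of trifluoromethyl. Going by these compounds, whether a pyridine ring could replace the benzene ring is also open.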